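From Nitro to Bromo: Compound 3 Awaits Its Number

The source may report more compounds than this note shows. Statements on the series, on what has been measured and on what is new or still open speak of the compounds shown alone.

In a functional assay on DU-145 cells (Homo sapiens) for inhibition, read by trypan blue exclusion, with a stated time of 96 h (a lower number here means a stronger inhibitor of growth, a higher number a weaker inhibitor of growth), compound 2 `Cc1ccsc1/C=C(/SCc1ccc(Cl)cc1)C(=O)c1ccc([N+](=O)[O-])cc1` stands at > 100000 nM and that value is a limit of the assay, not a number. Compound 3 `Cc1ccsc1/C=C(/SCc1ccc(Cl)cc1)C(=O)c1ccc(Br)cc1` differs from compound 2 in one place, on an aromatic carbon of a six-membered aromatic ring of carbon only, para to a large group: bromo stands in place of nitro (bromo in place of nitro on an aromatic carbon) and nothing else changes. For the measured compounds named here, no measured pair shows this change alone, so the size of the step is uncertain. Going by the values given here, the one guide is compound 1 `O=C(/C(=C\c1cc(Cl)cc(Cl)c1Cl)SCc1ccc(Cl)cc1)c1ccc(Br)cc1` which also carries a 4-bromophenyl and gives 1000 nM in this assay as a true number. A large move toward stronger growth inhibition is therefore expected, and the estimated step of an at least 25-fold lower number from compound 2 to compound 3 (1.39 log units; beyond the scatter) remains rough. For compound 3 the estimate is 4000 nM with an expected range from 700 nM to 30000 nM for the measurement to come.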

Compound 3, concentration for 50% growth inhibition: 25000 nM
For compound 3 the middle estimate is 6.3-fold (0.80 log units) below the measured one, within the range that was stated.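

In this assay, for the compounds shown here, bromo in place of nitro on this aromatic carbon gives an at least 4.0-fold lower number from compound 2 to compound 3 (0.60 log units; beyond the scatter), the first reading of this change alone, with the 3-methylthiophen-2-yl group held in place. That step can be read only as a bound, because the value of compound 2 is a limit and not a number: the limit of > 100000 nM in this assay, at which 1 of the 3 values shown sits. The 4-bromophenyl alone does not set the level of growth inhibition, as 3-methylthiophen-2-yl in place of 2,3,5-trichlorophenyl gives a 25-fold higher number from compound 1 to compound 3 (1.40 log units; beyond the scatter).

Still open, from the compounds shown here alone, is how an amine, a carboxylic acid or a methoxy group on the same aromatic carbon would compare with bromo. Going by these compounds, it is also open whether bromo in place of nitro would give a step of similar size with the 2,3,5-trichlorophenyl group in the molecule.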